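Ethyl for (tert-butyl)carbonyl on the shared core

A few compounds are considered here, and "the series" means these few. Any claim that something is new, unique, unknown or untested is made for them only; others in the source may bear on it.

Of the compounds shown here, two have been measured so far. In a functional assay on HT-29 cells (Homo sapiens) for cytotoxicity, read by MTT assay (a lower number here means a stronger inhibitor, a higher number a weaker inhibitor), compound 1 (`CCO[C@@H]1OC(=O)[C@](C)(C(C)=O)[C@@H]1C`) gives > 50000 nM, which is a limit of the assay and not a number. In this assay, among the measured compounds shown here, compound 2 (`CC(=O)[C@]1(C)C(=O)O[C@@H](OC(=O)C(C)(C)C)[C@H]1C`) gives 9000 nM, the only true number so far.

The next compound is compound 3 (`CCO[C@@H]1OC(=O)[C@@](C)(C(C)=O)[C@@H]1C`). The change from compound 2 is ethyl in place of (tert-butyl)carbonyl on an oxygen on a saturated carbon. For the measured compounds named here, no measured pair differs in one place only, so the size of this change has not been seen directly.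

Compound 1 also holds ethyl on that oxygen, and the expectation of weaker inhibition rests on the limit of compound 1, > 50000 nM. A step beyond the usual scatter is expected, estimated as a 5.6-fold higher number from compound 2 to compound 3 (0.74 log units; beyond the scatter). Compound 3 is estimated at 50000 nM, with an expected range of 15000 nM to 150000 nM, and a report as a limit alone would not be a surprise.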

Compound 3, half-maximal inhibitory concentration: > 50000 nM
Compound 3 was reported as a limit; the forecaster's own chance of this, stated with the estimate: 65%; the middle value lies on the limit itself.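

Ethyl in place of (tert-butyl)carbonyl on the oxygen now has a direct reading in this assay, and it goes against ethyl: an at least 5.5-fold higher number from compound 2 to compound 3 (0.74 log units; beyond the scatter) is a step beyond the usual scatter. Among the compounds shown here, this is the first step with a readable direction, and it places the only true number, that of compound 2, with the (tert-butyl)carbonyl group rather than with ethyl. The step between compound 1 and compound 3 cannot be read, so the drawn configuration at the saturated ring carbon has no measured effect in either direction, and the ethyl compounds share one reported limit: the limit of > 50000 nM in this assay, at which 2 of the 3 values shown sit.

Going by these compounds, the true size of the step remains open, since the value for compound 3 is a limit of the assay and not a number, and with ethyl on the oxygen neither configuration gives a value to compare. Also open, on these data alone, is which part of (tert-butyl)carbonyl goes with the measured value of compound 2, a question that an acetyl group or a longer chain such as n-butyl on that oxygen would bear on.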